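The source may hold more compounds than are shown below. What is called first, only, known or untested is meant among the compounds shown, and "the series" means these compounds.

Compound 1 `Cc1ccccc1/C=C1\CN(C(=S)NC(=O)c2ccccc2)C/C(=C\c2ccccc2C)C1=O` gives in a functional assay on DLD-1 cells (Homo sapiens) for antiproliferative activity, read by MTT assay, with a stated time of 48 h (on this read-out lower numbers stand for stronger inhibition and higher numbers for weaker inhibition), a value of < 10000 nM, which is a limit of the assay and not a number. Compound 2 `Cc1ccc(/C=C2\CN(C(=S)NC(=O)c3ccccc3)C/C(=C\c3ccc(C)cc3)C2=O)cc1` gives in this assay a value of < 10000 nM, again a limit of the assay. Compound 3 `CCCCNC(=S)N1C/C(=C\c2ccccc2C)C(=O)/C(=C/c2ccccc2C)C1` gives in this assay a value of < 10000 nM, also a limit.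

Compound 1 and compound 2 are built from the same atoms joined differently; the difference between their cores is not broken down here. Compound 3 arises from compound 1 by one change, (butyl in place of benzoyl on an amide-type nitrogen). The size of the step that the two limits leave unreadable from compound 1 to compound 3 cannot be read because of the limit of < 10000 nM in this assay, at which 3 of the 3 values shown sit.

Compound 4 `CCCCNC(=S)N1C/C(=C\c2ccc(C)cc2)C(=O)/C(=C/c2ccc(C)cc2)C1` is not yet measured and arises from compound 2 by the same change, at the same place, (butyl in place of benzoyl on an amide-type nitrogen). What can be expected of compound 4 rests only on the observation that (the limit of < 10000 nM in this assay, at which 3 of the 3 values shown sit). Compound 4 is therefore estimated to give about 3000 nM in this assay, between 500 nM and 9500 nM, and most probably it will again be reported only as a limit. The step that the limit leaves unreadable from compound 2 to compound 4 is accordingly expected to be small.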

Compound 4, half-maximal inhibitory concentration: < 10000 nM
Compound 4 was reported as a limit; the forecaster's own chance of this, stated with the estimate: 75%; the middle value is on the limit's open side.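

No size can be read for the step between compound 2 and compound 4, because both are reported only as limits and not as numbers: the limit of < 10000 nM in this assay, at which 4 of the 4 values shown sit.

The compounds shown leave open where any of them truly lies beyond that limit, and so whether butyl in place of benzoyl on an amide-type nitrogen changes the read-out at all.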